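The source may hold more compounds than are shown below. What is called first, only, known or untested is meant among the compounds shown, and "the series" means these compounds.

Of the compounds shown here, three have been measured in a functional assay on HeLa cells (Homo sapiens) for antiproliferative activity, read by MTT assay, with a stated time of 48 h; on this read-out lower numbers stand for stronger inhibition and higher numbers for weaker inhibition: compound 1, `Cc1cnc(Nc2ccc([N+](=O)[O-])cc2)nc1Nc1nc2ccccc2s1`, gives 34300 nM; compound 2, `COc1ccc2nc(Nc3ccnc(Nc4ccc(S(C)(=O)=O)cc4)n3)sc2c1`, gives 4130 nM; compound 3, `Cc1cnc(Nc2ccc(S(C)(=O)=O)cc2)nc1Nc1nc2ccc(Cl)cc2s1`, gives 4180 nM.

Compound 1 stands at the highest number of the three, which here means the weakest inhibition of cell growth. Compound 2 and compound 3 both sit at lower numbers, and each of those gaps lies beyond the usual scatter. Compound 4, `COc1ccc(Nc2ncc(C)c(Nc3nc4ccccc4s3)n2)cc1`, has not yet been measured. It differs from compound 1 in a single place: methoxy in place of nitro on an aromatic carbon. Among the measured compounds shown here, no measured pair shows this same change, so nothing in the data fixes its size or direction. The expectation is a modest step, a 1.4-fold lower number from compound 1 to compound 4 (0.14 log units; within the scatter), that stays within the scatter rather than a clear gain or loss. Compound 4 is therefore estimated at 25000 nM, with a range from 8000 nM to 80000 nM.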

Compound 4, half-maximal inhibitory concentration: > 50000 nM
Compound 4: no number, only a limit; the forecaster's own chance of this, stated with the estimate: 10%; middle value at least 2.0-fold (0.30 log units) away from the limit.
By their numbers in this assay, from the lowest: compounds 2 and 3 (each within the scatter of the next); then compound 1. At a limit, above all of these: compound 4.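

In this assay, compound 4 gives > 50000 nM, which is a limit of the assay and not a number. Methoxy in place of nitro at this position therefore gives an at least 1.4-fold higher number from compound 1 to compound 4 (0.16 log units; that floor lies within the scatter), so the change shows no sign of a gain here, though its true size stays unknown. This reading rests on a single compound at the limit: the limit of > 50000 nM in this assay, at which 1 of the 4 values shown sits.

The compounds shown leave open how an amine or a carboxylic acid at this position would compare with nitro and methoxy. From the compounds shown here alone, whether the same change would give a similar step on a different core also stays open.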